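Working notes: from compound 2 to compound 4

This account rests on a few compounds, and the source may have more. Where it says the series, first, only, none or still open, it means among the compounds named here.

Values from a toxicity assay on NIH3T3 cells (Mus musculus) for cytotoxicity, read by resazurin assay (on this read-out higher numbers stand for an effect only at larger amounts of compound and lower numbers for an effect already at smaller amounts), as measured so far
compound 1 (`COC(=O)c1ccc(NCc2cncn2Cc2ccccc2)cc1-c1ccccc1`) gives > 1000 nM as a limit
compound 2 (`Cc1cccc(-c2cccc(NCc3cncn3Cc3ccccc3)c2)c1C`) gives > 1000 nM as a limit
compound 3 (`CCOC(=O)c1ccc(NCc2cncn2Cc2ccc(-c3ccccc3)cc2)cc1-c1ccccc1`) gives > 10000 nM as a limit

Compound 2 stands at > 1000 nM as a limit and not a number, a place it shares with compound 1 (the limit of > 1000 nM in this assay, at which 2 of the 3 values shown sit). Compound 3 also stands at > 10000 nM as a limit. Compound 4 (`c1ccc(Cn2cncc2CNc2cccc(-c3ccncc3)c2)cc1`) carries pyridin-4-yl in place of 2,3-dimethylphenyl on an aromatic carbon. Among the compounds with values here, no measured step is available to scale this change. In this assay the estimate is a step that the limit leaves unreadable from compound 2 to compound 4 in the direction of an effect only at larger amounts, and no move toward smaller amounts is expected. For compound 4 the expected value is 3000 nM (estimated range 1000 nM to 10000 nM), and a report of a limit alone is likely.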

Compound 4, half-maximal effective concentration: > 1000 nM
Compound 4: no number, only a limit; the forecaster's own chance of this, stated with the estimate: 75%; the middle value is on the limit's open side.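

No step can be read between compound 2 and compound 4, as both stand only as limits and not as numbers: the limit of > 1000 nM in this assay, at which 3 of the 4 values shown sit.

The compounds shown leave open what pyridin-4-yl in place of 2,3-dimethylphenyl does to the half-maximal effective concentration.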